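From 3-Nitrophenyl to 4-Bromophenyl on the Shared Core

The source may hold more compounds than are shown below. What is called first, only, known or untested is meant among the compounds shown, and "the series" means these compounds.

Measured in a functional assay on HepG2 cells (Homo sapiens) for inhibition, read by MTT assay, with a stated time of 72 h; a lower number here means a stronger inhibitor, a higher number a weaker inhibitor:
- Compound 1 `COc1ccccc1-n1c(-c2coc3cc(C)c(Cl)cc3c2=O)nc(-c2ccccc2)c1-c1ccccc1`: 12500 nM
- Compound 2 `Cc1cc2occ(-c3nc(-c4ccccc4)c(-c4ccccc4)n3-c3ccc(Cl)cc3)c(=O)c2cc1Cl`: 1560 nM
- Compound 3 `Cc1cc2occ(-c3nc(-c4ccccc4)c(-c4ccccc4)n3-c3cccc([N+](=O)[O-])c3)c(=O)c2cc1Cl`: 25000 nM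

Compound 3 shares the weak end of these numbers with compound 1, as the data show a 2.0-fold higher number from compound 1 to compound 3 (0.30 log units; within the scatter). The next change puts 4-bromophenyl in place of 3-nitrophenyl on an aromatic nitrogen, giving compound 4 `Cc1cc2occ(-c3nc(-c4ccccc4)c(-c4ccccc4)n3-c3ccc(Br)cc3)c(=O)c2cc1Cl` (4-bromophenyl in place of 3-nitrophenyl on an aromatic nitrogen). The closest guide is compound 2, which carries 4-chlorophenyl on that nitrogen. The measured steps are a 16-fold higher number from compound 2 to compound 3 (1.20 log units; beyond the scatter) and an 8.0-fold lower number from compound 1 to compound 2 (0.90 log units; beyond the scatter). A large step to a lower number is therefore expected in this assay, if 4-bromophenyl behaves like 4-chlorophenyl. The estimated change is a 13-fold lower number from compound 3 to compound 4 (1.10 log units; beyond the scatter). The expected value for compound 4 is 2000 nM, within an estimated range of 700 nM to 6000 nM.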

Compound 4, half-maximal inhibitory concentration: 6250 nM
Compound 4: middle estimate off by 3.1-fold (0.49 log units), on the low side; measured number outside the range, above it.
By their numbers in this assay, from the lowest: compound 2; then compounds 4, 1 and 3 (each within the scatter of the next, the first and the last beyond it).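

In this assay, 4-bromophenyl in place of 3-nitrophenyl does bring a gain (a 4.0-fold lower number from compound 3 to compound 4 (0.60 log units; beyond the scatter)), but the gain stops short of the one seen with the chloro analogue. Exchanging just one halogen on this ring matters, since bromo in place of chloro gives a clear loss (a 4.0-fold higher number from compound 2 to compound 4 (0.60 log units; beyond the scatter)), while compound 4 cannot be separated from the 2-methoxyphenyl compound (a 2.0-fold lower number from compound 1 to compound 4 (0.30 log units; within the scatter)). Nothing available explains the gap between the two halogens. Still open, from the compounds shown here alone, is how fluoro, an amine or a carboxylic acid would behave in place of that bromo.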